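A few compounds are considered here, and "the series" means these few. Any claim that something is new, unique, unknown or untested is made for them only; others in the source may bear on it.

Measured so far:
- compound 1 `COC(=O)/C=C/c1cccc(N(Cc2ccc(/C=C/c3cccc(C(F)(F)F)c3)cc2)C(=O)C(C)C)c1`: 267 nM
- compound 2 `COC(=O)/C=C/c1cccc(N(Cc2ccc(/C=C/c3cccc(C(F)(F)F)c3)cc2)C(=O)NC(C)C)c1`: 932 nM
- compound 3 `CCOc1cccc(-c2ccc(CN(C(=O)C(C)C)c3cccc(/C=C/C(=O)OC)c3)cc2)c1`: 173 nM

These three compounds were tested in an assay on isolated protein with Bile acid receptor (Homo sapiens) as the target; on this read-out lower numbers stand for an effect already at smaller amounts and higher numbers for an effect only at larger amounts of compound. Among them compound 2 gives the highest number: compound 1 sits nearest, with a 3.5-fold higher number from compound 1 to compound 2 (0.54 log units; beyond the scatter) separating the two, and compound 3 sits furthest away. Going by the values given here, the only difference between compound 1 and compound 2 is isopropylamino in place of isopropyl on a carbonyl carbon, so compound 2 carries the urea form of the shared core.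

Compound 4 `COC(=O)/C=C/c1cccc(N(Cc2ccc(-c3ccc(C)cc3)cc2)C(=O)NC(C)C)c1` is not yet measured. It differs from compound 2 in one place: 4-methylphenyl in place of 2-(3-(trifluoromethyl)phenyl)ethenyl on an aromatic carbon. Among the compounds with values here, the change of most use for judging this is the one from compound 1 to compound 3, where the same 2-(3-(trifluoromethyl)phenyl)ethenyl group was exchanged for a small aryl group, 3-ethoxyphenyl, and the result was a 1.5-fold lower number from compound 1 to compound 3 (0.19 log units; within the scatter), a shift that stays within the scatter. Within the data shown here, no measured pair shows 4-methylphenyl itself, so the expectation rests on that single comparison. On that basis the step from compound 2 to compound 4 in this assay is expected to be small, a 1.2-fold lower number from compound 2 to compound 4 (0.07 log units; within the scatter), with no clear direction beyond the scatter. Compound 4 is therefore estimated at 800 nM in this assay, with a likely range from 300 nM to 2500 nM.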

Compound 4, half-maximal effective concentration: 449 nM
Estimate against measurement, compound 4: 1.8-fold (0.25 log units) above; measured number inside the range.
By their numbers in this assay, from the lowest: compounds 3, 1 and 4 (each within the scatter of the next, the first and the last beyond it); then compound 2.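

In this assay, the urea form of the core now shows a 2.1-fold lower number from compound 2 to compound 4 (0.32 log units; beyond the scatter) when 4-methylphenyl, with 7 heavy atoms, replaces the 12-atom 2-(3-(trifluoromethyl)phenyl)ethenyl group, so the shorter group does not cost activity here. Going by these compounds alone, the earlier exchange at this position, a 1.5-fold lower number from compound 1 to compound 3 (0.19 log units; within the scatter), stayed within the scatter and used a different aryl group on the non-urea form, so only this new step moves the number beyond the scatter, and only modestly. No measured property of these groups is available to explain the shift.

The ethenyl link, the trifluoromethyl group and the added methyl all change together, so a 4-(trifluoromethyl)phenyl group would be needed to begin separating them. Going by these compounds, it also remains open whether the step would hold with a carboxylic acid in place of the methyl ester.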